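Phenyl in place of methyl on an amide-type nitrogen

The source may report more compounds than this note shows. Statements on the series, on what has been measured and on what is new or still open speak of the compounds shown alone.

Compound 3 `CNC(=S)Nc1cccc(OCCCCCc2ccccc2)c1` was tested in an ADME assay on Ava5 cells (Homo sapiens) for cytotoxicity; a lower number here means that less compound is tolerated, a higher number that more compound is tolerated. In this assay compound 3 gives > 50000 nM, which is a limit of the assay and not a number. Compound 1 `NC(=S)Nc1cccc(OCCCc2ccccc2)c1` gives > 50000 nM in this assay, also a limit. Compound 2 `NC(=S)Nc1cccc(OCCCCc2ccccc2)c1` gives > 50000 nM in this assay, again a limit. For the measured compounds named here, the only step between measured compounds, a step that the two limits leave unreadable from compound 1 to compound 2, stays unreadable because the limit of > 50000 nM in this assay, at which 3 of the 3 values shown sit, covers both of its values. Compound 4 `S=C(Nc1ccccc1)Nc1cccc(OCCCCCc2ccccc2)c1` differs from compound 3 by phenyl in place of methyl on an amide-type nitrogen. Going by the values given here, no measured step bears on this change, so no movement beyond the scatter is expected. The expected step that the limit leaves unreadable from compound 3 to compound 4 is therefore none. Compound 4 is estimated at 60000 nM, between 20000 nM and 200000 nM.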

Compound 4, half-maximal cytotoxic concentration: 35000 nM
Beside the measured number, compound 4's estimate is 1.7-fold (0.23 log units) above it; low and high end bracket the measured number.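

In this assay, for the compounds shown here, compound 4 is the first compound here to give a number and not a limit, so a phenyl on this amide-type nitrogen brings the value within the range of the assay. The change from methyl to phenyl gives an at least 1.4-fold lower number from compound 3 to compound 4 (0.15 log units; that floor lies within the scatter) and so need not exceed the scatter. Its true size stays unreadable because one end of the step is a limit: the limit of > 50000 nM in this assay, at which 3 of the 4 values shown sit.

Going by these compounds, what a benzyl, a cyclohexyl or a pyridyl on this nitrogen would give stays open. So does whether a phenyl carrying an amine would give a similar number.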